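Notes on compound 3 before measurement

The compounds below may be only part of what the source reports. "The series", "measured", "known", "first", "only" and "open" are said of these compounds alone.

Compound 1 `CCCCc1nc(Cl)c(COC(=O)CCCCO[N+](=O)[O-])n1Cc1ccc(-c2ccccc2-c2nn[nH]n2)cc1`: 100%
Compound 2 `CCCCc1nc(Cl)c(COC(=O)c2cccc(CO[N+](=O)[O-])c2)n1Cc1ccc(-c2ccccc2-c2nn[nH]n2)cc1`: 100%

In a functional assay on the whole organism (aorta, strain Wistar) with Rattus norvegicus as the target (on this read-out higher numbers stand for larger maximal responses and lower numbers for smaller maximal responses), compound 1 gives 100% and compound 2 gives 100%. Compound 2 therefore stands level with compound 1, the step being no change at the digits printed from compound 1 to compound 2 (within the scatter).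

Compound 3 `CCCCc1nc(Cl)c(COC(=O)c2ccc(CO[N+](=O)[O-])cc2)n1Cc1ccc(-c2ccccc2-c2nn[nH]n2)cc1` is the next member. Its difference from compound 2 is 4-((nitrooxy)methyl)phenyl in place of 3-((nitrooxy)methyl)phenyl on a carbonyl carbon.

For the measured compounds named here, the only measured step that bears on this ester change is no change at the digits printed from compound 1 to compound 2 (within the scatter), which lay within the scatter although it exchanged a chain for a ring. For compound 3 the expectation is again no step beyond the scatter, a number 2 percentage points lower from compound 2 to compound 3 (within the scatter). Compound 3 is thus estimated at 98%, with a range from 88% to 105%.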

Compound 3, largest response reached (Emax), in percent of the reference or control that the assay uses: 100%
Compound 3: middle estimate off by 2 percentage points, on the low side; low and high end bracket the measured number.
By their numbers in this assay, from the lowest: compounds 1, 2 and 3 (each within the scatter of the next).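

Placing 4-((nitrooxy)methyl)phenyl in place of 3-((nitrooxy)methyl)phenyl on the carbonyl carbon gives no change at the digits printed from compound 2 to compound 3 (within the scatter) in this assay, so this exchange between two ring isomers leaves the read-out unmoved. Against the 4-(nitrooxy)butyl chain, the 4-((nitrooxy)methyl)phenyl group gives no change at the digits printed from compound 1 to compound 3 (within the scatter), so the chain-for-ring exchange is flat for this isomer too. No measurement on hand accounts for this flat result.

On these data alone, whether the nitrooxy group is needed for the response stays open. A plain butyl or plain phenyl on the carbonyl carbon, or a free carboxylic acid in place of the ester, lies outside the compounds shown.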